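This account rests on a few compounds, and the source may have more. Where it says the series, first, only, none or still open, it means among the compounds named here.

Compounds measured in an ADME assay on microsomes from liver (Homo sapiens) for metabolic stability, tested at 2.5 uM; a higher number here means faster removal of the compound, a lower number slower removal:
compound 1 `Fc1ccc(Cn2nnc3c(Br)cccc32)cc1`, 1.2 mL/min/g
compound 2 `Brc1ccc(Cn2nnc3c(Br)cccc32)cc1`, 0.4 mL/min/g

Among the compounds with values here, compound 1 stands highest of the two numbers in this assay; its only neighbour is compound 2, reached by a 3.0-fold lower number from compound 1 to compound 2 (0.48 log units; beyond the scatter). Compound 3 `Fc1ccc(Cn2nnc3c(Br)cccc32)c(Cl)c1` differs from compound 1 by chloro in place of hydrogen on an aromatic carbon. Within the data shown here, the single measured step, bromo in place of fluoro, is a different kind of change from chloro in place of hydrogen and bears only loosely here. Among the measured compounds shown here, with no matching step, no shift beyond the scatter is expected in this assay. Compound 3 is therefore estimated at 1 mL/min/g (range 0.4 mL/min/g to 2.5 mL/min/g). That estimate means an expected 1.2-fold lower number from compound 1 to compound 3 (0.08 log units; within the scatter).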

Compound 3, intrinsic clearance in a liver preparation (reported as CLH), per the amount of preparation that the assay uses: 1.8 mL/min/g
Compound 3: the middle estimate sits 1.8-fold (0.26 log units) below what was measured; the range from low to high includes it.
By their numbers in this assay, from the lowest: compound 2; then compounds 1 and 3 (each within the scatter of the next).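

In this assay chloro in place of hydrogen on an aromatic carbon, ortho to a large group and meta to a fluoro group, gives a 1.5-fold higher number from compound 1 to compound 3 (0.18 log units; within the scatter) and so stays within the scatter. This position therefore accepts a chloro group without a clear shift in this read-out, whereas the earlier step, bromo in place of fluoro, gave a 3.0-fold lower number from compound 1 to compound 2 (0.48 log units; beyond the scatter) as a shift beyond the scatter. No evidence at hand accounts for this result.

As far as these compounds go, whether an amine or a methoxy group at this carbon would behave like chloro remains open. So does the outcome of the same chloro change on compound 2.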